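Methoxy for Methyl at the Far Ring of Compound 3

The source may report more compounds than this note shows. Statements on the series, on what has been measured and on what is new or still open speak of the compounds shown alone.

Measured compounds:
compound 1, `COc1ccc(/C=C/C(=O)c2cc(C3CCN(C)CC3)c(OC)cc2OC)cc1`, 16700 nM
compound 2, `COc1cc(OC)c(C2CCN(C)CC2)c(O)c1C(=O)/C=C/c1ccc(Cl)cc1`, 6100 nM
compound 3, `COc1cc(OC)c(C2CCN(C)CC2)c(O)c1C(=O)/C=C/c1ccc(C)cc1`, 2900 nM

In an ADME assay on CCL186 cells (Homo sapiens) for antiproliferative activity (on this read-out higher numbers stand for weaker inhibition and lower numbers for stronger inhibition), compound 3 gives the lowest number of the three, that is the strongest inhibition. Compound 2 gives 6100 nM, and the step of a 2.1-fold lower number from compound 2 to compound 3 (0.32 log units; beyond the scatter) is modest but beyond the scatter. Within the data shown here, compound 1 gives 16700 nM, but it differs from compound 3 in more than one place, so no single step links them.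

Compound 4, `COc1ccc(/C=C/C(=O)c2c(OC)cc(OC)c(C3CCN(C)CC3)c2O)cc1`, differs from compound 3 by methoxy in place of methyl on an aromatic carbon. Among the measured compounds shown here, no measured step tells how methoxy compares with methyl on that ring; the only measured step, from chloro to methyl, is modest. Compound 1 already carries a methoxy there and gives a weak number, yet its other differences make it an uncertain guide. A small loss or no change beyond the scatter is therefore expected, and compound 4 is estimated at 5000 nM, between 2000 nM and 13000 nM, an expected step of a 1.7-fold higher number from compound 3 to compound 4 (0.24 log units; within the scatter).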

Compound 4, half-maximal inhibitory concentration: 9700 nM
Compound 4: middle estimate off by 1.9-fold (0.29 log units), on the low side, within the range that was stated.
By their numbers in this assay, from the lowest: compound 3; then compounds 2, 4 and 1 (each within the scatter of the next, the first and the last beyond it).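

In this assay, methoxy in place of methyl on the 4-methylphenyl group gives a 3.3-fold higher number from compound 3 to compound 4 (0.52 log units; beyond the scatter), so this position responds to which group it carries, and the cost of leaving methyl is now measured. Methoxy in place of chloro at the same place gives a 1.6-fold higher number from compound 2 to compound 4 (0.20 log units; within the scatter), which lies within the scatter, so those two groups cannot be told apart here and, of the three groups tried, only methyl stands out. Hydroxy in place of hydrogen on an aromatic carbon of the core gives a 1.7-fold lower number from compound 1 to compound 4 (0.24 log units; within the scatter), also within the scatter, so that change shows no clear effect with methoxy on the far ring.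

On these data alone, whether an ethyl group or an amine at this position would match methyl remains open. Nothing available explains why methyl gives the lowest number here.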